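Swapping a Cyclobutyl Amide for a Pyridinylmethyl Amide

The compounds below may be only part of what the source reports. "The series", "measured", "known", "first", "only" and "open" are said of these compounds alone.

Compound 1, `CCC[C@H](NC(=O)[C@@H]1C[C@@H]2CN1C(=O)[C@H](C(C)(C)C)NC(=O)OCCCCCCc1cccc3c1CN(C3)C(=O)O2)C(=O)C(=O)CC1CC1`, gives > 50000 nM in an ADME assay on Huh-7 cells (Homo sapiens) for cytotoxicity; a lower number here means that less compound is tolerated, a higher number that more compound is tolerated; this is a limit of the assay, not a number.
Compound 2, `CCC[C@H](NC(=O)[C@@H]1C[C@@H]2CN1C(=O)[C@H](C(C)(C)C)NC(=O)OCCCCCCc1cccc3c1CN(C3)C(=O)O2)C(=O)C(=O)NC1CCC1`, gives > 50000 nM in this assay; this too is a limit.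
Compound 3, `CCC[C@H](NC(=O)[C@@H]1C[C@@H]2CN1C(=O)[C@H](C(C)(C)C)NC(=O)OCCCCCCc1cccc3c1CN(C3)C(=O)O2)C(=O)C(=O)NC1CCCC1`, gives > 50000 nM in this assay; this too is a limit.

Compound 2 thus stands on a limit only, and the two other values shown sit at the same place, as the limit of > 50000 nM in this assay, at which 3 of the 3 values shown sit, states. Because all three values are limits, none of the steps among them can be read: a step that the two limits leave unreadable from compound 1 to compound 2, a step that the two limits leave unreadable from compound 1 to compound 3 and a step that the two limits leave unreadable from compound 2 to compound 3. The measured compounds differ from one another only in the group carried on the amide-type nitrogen or on the carbonyl carbon, and no such change has yet moved a value off the limit.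

Compound 4, `CCC[C@H](NC(=O)[C@@H]1C[C@@H]2CN1C(=O)[C@H](C(C)(C)C)NC(=O)OCCCCCCc1cccc3c1CN(C3)C(=O)O2)C(=O)C(=O)NCc1ccccn1`, differs from compound 2 by (pyridin-2-yl)methyl in place of cyclobutyl on an amide-type nitrogen. The three measured steps bear on this change only in that every variation of this end of the molecule has left the value at the limit; they give no readable size. The expected step in this assay is therefore a number no higher from compound 2 to compound 4 (the limit leaves the size open), with no direction beyond the scatter. Compound 4 is expected to give about 50000 nM, within a range from 20000 nM to 100000 nM.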

Compound 4, half-maximal cytotoxic concentration: > 50000 nM
Compound 4: a limit, no number; the forecaster's own chance of this, stated with the estimate: 75%; the middle value lies on the limit itself.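

In this assay compound 4 gives > 50000 nM, which is a limit, not a number. The steps to it from compound 1, compound 2 and compound 3 cannot be read, because all four compounds sit at the same mark: the limit of > 50000 nM in this assay, at which 4 of the 4 values shown sit. The compounds shown leave open whether cyclobutyl, cyclopentyl and (pyridin-2-yl)methyl on the amide-type nitrogen differ at all in how much compound the cells tolerate.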